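A Shorter Ring on the Long-Chain Analogue

The compounds below may be only part of what the source reports. "The series", "measured", "known", "first", "only" and "open" are said of these compounds alone.

Of the compounds shown here, three have been measured in a functional assay on DU-145 cells (Homo sapiens) for inhibition, read by MTT assay, with stated times of 18 h and 4 h; on this read-out lower numbers stand for stronger inhibition and higher numbers for weaker inhibition. Compound 1 `CCCCCCOP(=O)(O)OCCSC(=S)N1CCCC1` and compound 2 `CCCCCCOP(=O)(O)OCCSC(=S)N1CCCCC1` share the shorter chain on the common core, while compound 3 `CCCCCCCCCCCCCCCCOP(=O)(O)OCCSC(=S)N1CCCCC1` carries the longer one. In this assay compound 1 reaches only the limit of the assay, > 100000 nM. Compound 2 likewise gives only a limit, > 100000 nM. Going by the values given here, compound 3 is the one compound with a number, 14700 nM. The difference between compound 2 and compound 1 is pyrrolidin-1-yl in place of piperidin-1-yl on a thiocarbonyl carbon, and the step that the two limits leave unreadable from compound 2 to compound 1 cannot be read because of the limit of > 100000 nM in this assay, at which 2 of the 3 values shown sit. The difference between compound 2 and compound 3 is decyl in place of hydrogen on a saturated chain carbon, six bonds along the chain from an oxygen on an unsaturated carbon, and this step an at least 6.8-fold lower number from compound 2 to compound 3 (0.83 log units; beyond the scatter) is clear.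

Compound 4 `CCCCCCCCCCCCCCCCOP(=O)(O)OCCSC(=S)N1CCCC1` is not yet measured; it differs from compound 3 by pyrrolidin-1-yl in place of piperidin-1-yl on a thiocarbonyl carbon, the same change as that between compound 2 and compound 1. Since that earlier step stays unreadable, the expectation for compound 4 rests on compound 3 alone, with its value 14700 nM. The step of a 1.0-fold higher number from compound 3 to compound 4 (0.01 log units; within the scatter) is expected to be small. Compound 4 is therefore estimated at 15000 nM, between 5000 nM and 45000 nM.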

Compound 4, half-maximal inhibitory concentration: 28900 nM
Estimate against measurement, compound 4: 1.9-fold (0.28 log units) below, and the stated range covers the measured number.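

In this assay, pyrrolidin-1-yl in place of piperidin-1-yl on a thiocarbonyl carbon gives a 2.0-fold higher number from compound 3 to compound 4 (0.29 log units; within the scatter), so on the long-chain core the two rings cannot be told apart on this read-out. Decyl in place of hydrogen on a saturated chain carbon gives an at least 3.4-fold lower number from compound 1 to compound 4 (0.53 log units; beyond the scatter), and this change points the same way with either ring, though the size of any difference between the two cases stays unknown: the same change on two cores in this assay, an at least 6.8-fold lower number (0.83 log units; beyond the scatter) from compound 2 to compound 3 and an at least 3.4-fold lower number (0.53 log units; beyond the scatter) from compound 1 to compound 4; the limit leaves it open whether they differ The ring change itself cannot be compared between the two cores, because its step on the shorter chain cannot be read: the limit of > 100000 nM in this assay, at which 2 of the 4 values shown sit.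

The compounds shown leave open how a diethylamino group in place of either ring would read on this core. They also leave open whether the two rings would remain indistinguishable with a longer chain, and where compounds with a chain of intermediate length would fall.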